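The source may report more compounds than this note shows. Statements on the series, on what has been measured and on what is new or still open speak of the compounds shown alone.

Measured values in an assay on membranes from HeLa cells for displacement of a labelled ligand from adenosine receptor A3 (Homo sapiens), read by scintillation counting, with a stated time of 180 min, tested at 1 uM; on this read-out higher numbers stand for more inhibition at the one concentration tested (going by the name of the read-out) and lower numbers for less inhibition:
- compound 1 `CCCOC(=O)C1=C(C)NC(=O)NC1c1cccs1`: 32%
- compound 2 `CC1=C(C(=O)CC(C)C)C(c2cccs2)NC(=O)N1`: 18%
- compound 3 `CC1=C(C(=O)OCC2CC2)C(c2ccco2)NC(=O)N1`: 1%

Compound 3 stands lowest of the three numbers; compound 2 is nearest to it and compound 1 furthest, both gaps beyond the scatter. Compound 4 `CC1=C(C(=O)OCC2CC2)C(c2cccs2)NC(=O)N1` differs from compound 3 by thiophen-2-yl in place of furan-2-yl on a saturated ring carbon. For the measured compounds named here, the only measured step, a number 14 percentage points lower from compound 1 to compound 2 (beyond the scatter), changes a different part of the shared core and so says nothing about this ring swap. Compounds 1 and 2 carry the ring that enters and give higher numbers than compound 3, but each also differs from compound 4 at the carbonyl side, so those numbers bear on compound 4 only indirectly. A modest rise is expected, a number 13 percentage points higher from compound 3 to compound 4 (beyond the scatter). Compound 4 is therefore estimated at 14%, from 0% to 32%.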

Compound 4, a percentage reported as inhibition, at one concentration (the size of the read-out at that concentration, not a potency): 1%
The estimate for compound 4 lay 13 percentage points above the measured number; the measured number falls inside the stated range.
By their numbers in this assay, from the lowest: compounds 3 and 4 (each within the scatter of the next); then compound 2; then compound 1.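

In this assay, the ring swap gives no change at the digits printed from compound 3 to compound 4 (within the scatter), so with cyclopropylmethoxy on the carbonyl carbon, thiophen-2-yl and furan-2-yl on the saturated ring carbon do not separate these compounds. The carbonyl side matters more here, with a number 17 percentage points lower from compound 2 to compound 4 (beyond the scatter) for cyclopropylmethoxy in place of isobutyl and a number 31 percentage points lower from compound 1 to compound 4 (beyond the scatter) for cyclopropyl in place of ethyl. No evidence on the reason for these steps is available. Going by these compounds, whether the ring swap would also show no change with propoxy on the carbonyl carbon remains open. So does the effect of a phenyl ring on the saturated ring carbon.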